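The source may report more compounds than this note shows. Statements on the series, on what has been measured and on what is new or still open speak of the compounds shown alone.

Compound 2 `CCOC(=O)c1ccc(CO/N=C/c2c(C)nn(C)c2Oc2ccc(Cl)cc2)cc1` gives 20.9% in a functional assay on MKN-45 cells (Homo sapiens) for antiproliferative activity, tested at 1 uM; a higher number here means more inhibition at the concentration tested (going by the name of the read-out), a lower number less inhibition. For the measured compounds named here, of the two numbers in hand it stands lowest, but its only neighbour, compound 1 `COc1ccc(CO/N=C/c2c(C)nn(C)c2Oc2ccc(Cl)cc2)cc1`, lies within the scatter of it at 28.1%. Going by the values given here, the single step measured so far, a number 7.2 percentage points lower from compound 1 to compound 2 (within the scatter), concerns the same aromatic carbon that compound 3 `Cc1nn(C)c(Oc2ccc(Cl)cc2)c1/C=N/OCc1ccc([N+](=O)[O-])cc1` now varies: nitro in place of ethoxycarbonyl on an aromatic carbon. Since that one step stayed within the scatter, the swap of ethoxycarbonyl for nitro gives no ground, on this comparison alone, to expect a shift beyond the scatter in either direction in this assay. The expected step is therefore a number 1.1 percentage points higher from compound 2 to compound 3 (within the scatter), essentially flat. Compound 3 is accordingly estimated at 22% in this assay, with a range from 8% to 38%. This estimate rests only on the step of a number 7.2 percentage points lower from compound 1 to compound 2 (within the scatter), and a single comparison of that kind is a thin base, so the range is kept wide.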

Compound 3, a percentage reported as inhibition, at one concentration (the size of the read-out at that concentration, not a potency): 24.6%
For compound 3 the middle estimate is 2.6 percentage points below the measured one; low and high end bracket the measured number.
By their numbers in this assay, from the lowest: compounds 2, 3 and 1 (each within the scatter of the next).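

At the aromatic carbon para to a large group, three different substituents now give numbers within the scatter of one another in this assay, with a number 3.7 percentage points higher from compound 2 to compound 3 (within the scatter) and a number 3.5 percentage points lower from compound 1 to compound 3 (within the scatter) as the two new steps. Nitro has 3 heavy atoms against 5 in ethoxycarbonyl, yet this difference in count, at an equal count of hydrogen-bond acceptors, goes with no step beyond the scatter. Nothing measured here bears on why the numbers stay together at this position.

Open, going by these compounds, is whether an amine or a carboxylic acid on this carbon, or a longer chain ending in either group, would give a step beyond the scatter. Also open, on these data alone, is whether the flat picture for methoxy, ethoxycarbonyl and nitro holds when the rest of the shared core is changed.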